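The source may report more compounds than this note shows. Statements on the series, on what has been measured and on what is new or still open speak of the compounds shown alone.

Of the compounds shown here, two built on one shared core have been measured. Compound 1 `O=C(Nc1ccc(Cl)cc1)NS(=O)(=O)c1ccc(Cl)s1` gives 58% in a functional assay on the whole organism (6C3HED cells, Mus musculus) for inhibition, at a dose of 150 mg/kg by the oral route (on this read-out lower numbers stand for less inhibition and higher numbers for more inhibition at the one dose given (going by the name of the read-out)), and compound 2 `CCCc1ccc(S(=O)(=O)NC(=O)Nc2ccc(Cl)cc2)s1` gives 38% in this assay. Within the data shown here, the one measured step, a number 20 percentage points lower from compound 1 to compound 2 (beyond the scatter), goes beyond the scatter, so compound 2 stands lowest of the two numbers, with compound 1 the only other compound and above it.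

Compound 3 `CCCOc1ccc(S(=O)(=O)NC(=O)Nc2ccc(Cl)cc2)s1` differs from compound 2 in one place: propoxy in place of propyl on an aromatic carbon, on an aromatic carbon of a five-membered aromatic ring with one sulfur, next to the ring sulfur. Among the measured compounds shown here, no measured step speaks to propyl against propoxy; the only step known, from chloro to propyl, was modest and concerns a different change. In this assay the step from compound 2 to compound 3 is therefore expected to stay within the scatter, a number 2 percentage points higher from compound 2 to compound 3 (within the scatter). Compound 3 is estimated at 40%, with a range from 18% to 62%.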

Compound 3, a percentage reported as inhibition, in the whole organism at one dose (the size of the read-out at that dose, not a potency): 44%
The estimate for compound 3 lay 4 percentage points below the measured number, and the stated range covers the measured number.
By their numbers in this assay, from the lowest: compounds 2 and 3 (each within the scatter of the next); then compound 1.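

In this assay, putting propoxy in place of propyl on this aromatic carbon, next to the ring sulfur, gives a number 6 percentage points higher from compound 2 to compound 3 (within the scatter), so the added oxygen, with its one hydrogen-bond acceptor, does not set the two groups apart at this dose. Chloro at the same carbon is set apart from propoxy, as it was from propyl: the change gives a number 14 percentage points lower from compound 1 to compound 3 (beyond the scatter). Among these three compounds, then, the line falls between chloro and the two groups of three carbons, whether or not the chain is joined through oxygen.

From the compounds shown here alone, it remains open whether bromo, an amine, a carboxylic acid or a longer chain such as butoxy on this carbon would stand with compound 1 or with compound 2 and compound 3 in this assay. Nothing available bears on what lies behind these numbers.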